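This account rests on a few compounds, and the source may have more. Where it says the series, first, only, none or still open, it means among the compounds named here.

Compound 1, `O=C(O)c1ccccc1-c1ccc(CCc2ncc(CC3CCCC3)[nH]2)cc1`, gives 133 nM in an in vitro functional assay on cells for agonist activity at Bombesin receptor subtype-3 (Homo sapiens), read by luminescence and calcium flux; a lower number here means that less compound is needed, a higher number that more compound is needed for the effect.
Compound 2, `O=C(O)c1ccccc1-c1ccc(CCc2ncc(Cc3ccccc3F)[nH]2)cc1`, gives 177 nM.
Compound 3, `O=C(O)c1ccccc1-c1ccc(CCc2ncc(Cc3cccc(F)c3)[nH]2)cc1`, gives 159 nM.

The three numbers all lie within the usual scatter of one another. Compound 3 sits among them: the step of a 1.1-fold lower number from compound 2 to compound 3 (0.05 log units; within the scatter) and the step of a 1.2-fold higher number from compound 1 to compound 3 (0.08 log units; within the scatter) both stay within the scatter, so the three compounds cannot be told apart on these figures.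

Compound 4, `O=C(O)c1ccccc1-c1ccc(CCc2ncc(CCc3ccccc3)[nH]2)cc1`, carries the change (benzyl in place of 3-fluorophenyl on a saturated chain carbon bound to an aromatic carbon). The measured steps that bear on this place are a 1.3-fold higher number from compound 1 to compound 2 (0.12 log units; within the scatter), a 1.2-fold higher number from compound 1 to compound 3 (0.08 log units; within the scatter) and a 1.1-fold lower number from compound 2 to compound 3 (0.05 log units; within the scatter); every one of them stays within the scatter, so three different groups on this saturated chain carbon have given the same result. From that pattern compound 4 is expected to show no step beyond the scatter, namely a 1.0-fold higher number from compound 3 to compound 4 (0.00 log units; within the scatter). Compound 4 is therefore estimated at 160 nM, with a range from 70 nM to 360 nM.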

Compound 4, half-maximal effective concentration: 1320 nM
Beside the measured number, compound 4's estimate is 8.3-fold (0.92 log units) below it; the measured number lies above the stated range.
By their numbers in this assay, from the lowest: compounds 1, 3 and 2 (each within the scatter of the next); then compound 4.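

In this assay this saturated chain carbon turns out not to accept every group alike: an 8.3-fold higher number from compound 3 to compound 4 (0.92 log units; beyond the scatter) and a 7.5-fold higher number from compound 2 to compound 4 (0.87 log units; beyond the scatter) and a 9.9-fold higher number from compound 1 to compound 4 (1.00 log units; beyond the scatter) all lie beyond the scatter, while the steps among the three earlier compounds did not. Benzyl and 3-fluorophenyl match in heavy atoms and in their aromatic ring, so those counts do not separate the groups, yet read one bond further out the change is 3-fluorobenzyl to phenethyl, and the fluorine is lost with it. Nothing measured here explains the rise in the number.

The compounds shown leave open which part of the change carries the step: the loss of fluorine or the phenethyl chain itself. A 3-fluorophenethyl group would separate the two, and a 3-phenylpropyl chain would show what a longer chain does.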